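The source may hold more compounds than are shown below. What is called first, only, known or untested is meant among the compounds shown, and "the series" means these compounds.

Compound 1 `CNC(=O)c1cc(Oc2cccc(NS(=O)(=O)c3cccc(C(F)(F)F)c3)c2)ccn1` gives in a functional assay on PLC5 cells (Homo sapiens) for inhibition, read by MTT assay, with a stated time of 24 h (on this read-out higher numbers stand for weaker inhibition and lower numbers for stronger inhibition), a value of 8400 nM. Compound 2 `CNC(=O)c1cc(Oc2cccc(NCc3cccc(OC(F)(F)F)c3)c2)ccn1` sits at a limit of this assay, > 15000 nM, and not at a number. Compound 3 `Nc1cc(Oc2cccc(NCc3cccc(OC(F)(F)F)c3)c2)ccc1[N+](=O)[O-]` gives 8300 nM in this assay. The difference between the cores of compound 1 and compound 2 is not broken down here. From compound 2 to compound 3 the change is 3-amino-4-nitrophenyl in place of 2-(methylcarbamoyl)pyridin-4-yl on an oxygen on an aromatic ring, and the step is an at least 1.8-fold lower number from compound 2 to compound 3 (0.25 log units; that floor lies within the scatter), a floor only, because one value sits at the limit of > 15000 nM in this assay, at which 1 of the 3 values shown sits. Compound 4 `Nc1cc(Oc2cccc(NS(=O)(=O)c3cccc(C(F)(F)F)c3)c2)ccc1[N+](=O)[O-]` is not yet measured; it differs from compound 1 by 3-amino-4-nitrophenyl in place of 2-(methylcarbamoyl)pyridin-4-yl on an oxygen on an aromatic ring, the same change at the same place. Compound 1 and compound 3 lie within the scatter of each other. The step from compound 1 to compound 4 is expected to be a 1.2-fold lower number from compound 1 to compound 4 (0.08 log units; within the scatter), resting on compound 3 at 8300 nM and on an at least 1.8-fold lower number from compound 2 to compound 3 (0.25 log units; that floor lies within the scatter). Compound 4 is estimated at 7000 nM, between 2500 nM and 20000 nM.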

Compound 4, half-maximal inhibitory concentration: 3900 nM
For compound 4 the middle estimate is 1.8-fold (0.25 log units) above the measured one; the range from low to high includes it.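

In this assay, 3-amino-4-nitrophenyl in place of 2-(methylcarbamoyl)pyridin-4-yl gives a 2.2-fold lower number from compound 1 to compound 4 (0.33 log units; beyond the scatter), a modest step on the core of compound 1. Set beside the same change on the core of compound 2, the step points the same way on both cores, but the comparison goes no further: the same change on two cores in this assay, an at least 1.8-fold lower number (0.25 log units; that floor lies within the scatter) from compound 2 to compound 3 and a 2.2-fold lower number (0.33 log units; beyond the scatter) from compound 1 to compound 4; the limit leaves it open whether they differ. Compound 2 gives a limit and not a number, so the data show that the direction carries over but not that the size does: the limit of > 15000 nM in this assay, at which 1 of the 4 values shown sits.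

On these data alone, it stays open whether the amine or the nitro group alone would give this step. Also open, as far as these compounds go, is how a plain phenyl, or a carboxylic acid in place of the methylcarbamoyl group, would read in this assay.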